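Dimethylamino in Place of Hydroxy on the Fused Core

The compounds below may be only part of what the source reports. "The series", "measured", "known", "first", "only" and "open" are said of these compounds alone.

Compound 2 `Nc1ccc(-c2cc(=O)c3c(N)c(F)c(O)c(F)c3o2)cc1F` was tested in a functional assay on HeLa cells (Homo sapiens) for cytotoxicity, read by neutral red uptake, with a stated time of 3 days; on this read-out lower numbers stand for stronger inhibition and higher numbers for weaker inhibition. For compound 2 the result of > 100000 nM is a limit of the assay, not a number. Compound 1 `Nc1ccc(-c2cc(=O)c3c(N)c(F)c(Br)c(F)c3o2)cc1F` also gives only the limit > 100000 nM. Compound 3 `COc1c(F)c(N)c2c(=O)cc(-c3ccc(N)c(F)c3)oc2c1F` gives 34000 nM. The step that the two limits leave unreadable from compound 1 to compound 2 cannot be read because of the limit of > 100000 nM in this assay, at which 2 of the 3 values shown sit, whereas an at least 2.9-fold lower number from compound 2 to compound 3 (0.46 log units; beyond the scatter) and an at least 2.9-fold lower number from compound 1 to compound 3 (0.46 log units; beyond the scatter) are readable and point the same way. Compound 4 `CN(C)c1c(F)c(N)c2c(=O)cc(-c3ccc(N)c(F)c3)oc2c1F` differs from compound 2 by dimethylamino in place of hydroxy on an aromatic carbon. Since the step of an at least 2.9-fold lower number from compound 2 to compound 3 (0.46 log units; beyond the scatter) came from capping the same hydroxy, a modest lower number is expected here as well. Compound 4 is expected to give about 40000 nM in this assay, within 12000 nM to 130000 nM. That estimate means an expected step of an at least 2.5-fold lower number from compound 2 to compound 4 (0.39 log units; beyond the scatter).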

Compound 4, half-maximal inhibitory concentration: > 100000 nM
Compound 4: only a limit was reported (the forecaster's own chance of this, stated with the estimate: 35%); at least 2.5-fold (0.39 log units) between middle value and limit.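

At this position on the shared core, a dimethylamino group does not repeat what methoxy did: in this assay dimethylamino in place of methoxy gives an at least 2.9-fold higher number from compound 3 to compound 4 (0.46 log units; beyond the scatter) on the same aromatic carbon. Among the groups shown, therefore, the lower number belongs to methoxy alone, not to every replacement of hydroxy. The steps to compound 4 from compound 2 and from compound 1 cannot be read: the limit of > 100000 nM in this assay, at which 3 of the 4 values shown sit.

The compounds shown leave open whether a methylamino group or an ethoxy group, with its longer chain, would stay with methoxy or sit at the limit.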